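This account rests on a few compounds, and the source may have more. Where it says the series, first, only, none or still open, it means among the compounds named here.

Compounds measured so far:
compound 1 `Cc1ccc(NC(=S)NC(=O)c2ccc(OCc3cccc(Cl)c3)cc2)cc1-c1nc2ccccc2[nH]1`, > 100000 nM;
compound 2 `Cc1ccc(NC(=S)NC(=O)c2ccc(OCc3ccc(Cl)c(Cl)c3)cc2)cc1-c1nc2ccccc2[nH]1`, 30700 nM;
compound 3 `Cc1ccc(NC(=O)NC(=O)c2ccc(OCc3ccccc3)cc2)cc1-c1nc2ccccc2[nH]1`, 30100 nM.

In a functional assay on SW-620 cells (Homo sapiens) for inhibition, read by MTT assay, with a stated time of 48 h (on this read-out higher numbers stand for weaker inhibition and lower numbers for stronger inhibition), compound 1 gives only a limit of the assay, (the limit of > 100000 nM in this assay, at which 1 of the 3 values shown sits). Compound 3 and compound 2 sit within the usual scatter of each other, so neither can be called the stronger. Compound 4 `Cc1ccc(NC(=O)NC(=O)c2ccc(OCc3ccc(Cl)cc3Cl)cc2)cc1-c1nc2ccccc2[nH]1` differs from compound 3 by 2,4-dichlorophenyl in place of phenyl on a saturated chain carbon bound to an oxygen on an aromatic ring. For the measured compounds named here, the only comparable measured step is an at least 3.2-fold lower number from compound 1 to compound 2 (0.51 log units; beyond the scatter), where a chlorine was added on a benzyl ring, though that step starts from a limit and concerns a different pattern of chlorines. A modest lowering of the number is therefore expected: a 2.0-fold lower number from compound 3 to compound 4 (0.30 log units; within the scatter). Compound 4 is estimated at 15000 nM, with a range from 5000 nM to 60000 nM.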

Compound 4, half-maximal inhibitory concentration: 12200 nM
For compound 4 the middle estimate is 1.2-fold (0.09 log units) above the measured one; the range from low to high includes it.
By their numbers in this assay, from the lowest: compound 4; then compounds 3 and 2 (each within the scatter of the next). At a limit, above all of these: compound 1.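

In this assay, 2,4-dichlorophenyl in place of phenyl on this saturated chain carbon gives a 2.5-fold lower number from compound 3 to compound 4 (0.39 log units; beyond the scatter). This is the first chlorine step shown that has a measured number at both ends and starts from a benzyl ring carrying no chlorine. The earlier chlorine step started from compound 1, whose value is only a limit: the limit of > 100000 nM in this assay, at which 1 of the 4 values shown sits.

On these data alone, with both chlorines entering together, the share of each one stays open. Also open, as far as these compounds go, is what an amine or a carboxylic acid on this ring would give.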